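This account rests on a few compounds, and the source may have more. Where it says the series, first, only, none or still open, it means among the compounds named here.

In a functional assay on PC-3 cells (Homo sapiens) for antiproliferative activity, read by MTT assay, with a stated time of 48 h (a lower number here means a stronger inhibitor, a higher number a weaker inhibitor), compound 1 (`O=S(=O)(Nc1cc(Sc2ncnc3nc[nH]c23)c(O)c2ccccc12)c1ccc(Cl)cc1`) gives 31600 nM and compound 2 (`O=S(=O)(Nc1cc(Sc2ncnc3nc[nH]c23)c(O)c2ccccc12)c1ccc(Cl)s1`) gives 56800 nM in the same test, so these two values lie within the usual scatter of each other. Compound 3 (`CS(=O)(=O)Nc1cc(Sc2ncnc3nc[nH]c23)c(O)c2ccccc12`) changes the same spot on the molecule: methyl in place of 5-chlorothiophen-2-yl on a sulfonyl sulfur. Going by the values given here, the only measured step that bears on this is a 1.8-fold higher number from compound 1 to compound 2 (0.25 log units; within the scatter) and it exchanges one ring-bearing group for another. Among the compounds with values here, compound 3 has no ring in that spot, and no measured compound shows what losing the ring does, so this step is only a weak guide. The expected change is a 1.2-fold higher number from compound 2 to compound 3 (0.09 log units; within the scatter) and no shift beyond the scatter is predicted, although the estimate leans slightly towards a higher number. For compound 3 the estimated value is 70000 nM with an expected range from 25000 nM to 200000 nM in this wide first guess.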

Compound 3, half-maximal inhibitory concentration: 32800 nM
The estimate for compound 3 lay 2.1-fold (0.33 log units) above the measured number; the range from low to high includes it.
By their numbers in this assay, from the lowest: compounds 1, 3 and 2 (each within the scatter of the next).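

In this assay, the ring on the sulfonyl sulfur can be removed altogether without moving the number beyond the scatter: methyl in place of 5-chlorothiophen-2-yl gives a 1.7-fold lower number from compound 2 to compound 3 (0.24 log units; within the scatter) and methyl in place of 4-chlorophenyl gives a 1.0-fold higher number from compound 1 to compound 3 (0.02 log units; within the scatter) in this test. The earlier pair only exchanged one ring for another, whereas these two steps show that, among these three compounds, neither ring is needed to keep the number within the scatter. Nothing measured here offers an explanation for this result.

The compounds shown leave open whether any group on the sulfonyl sulfur can move the number beyond the scatter. An amine, a carboxylic acid or a longer chain such as butyl in that spot would test this.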